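A few compounds are considered here, and "the series" means these few. Any claim that something is new, unique, unknown or untested is made for them only; others in the source may bear on it.

Compound 1 `O=C(Nc1cccc(-n2cc(-c3ccncc3)c(-c3ccc(Cl)c(O)c3)n2)c1)Nc1ccc(Cl)c(Cl)c1`: > 32500 nM
Compound 2 `COc1cc(-c2nn(-c3cccc(NC(=O)c4ccc(Cl)c(C(F)(F)F)c4)c3)cc2-c2ccncc2)ccc1Cl`: > 32500 nM
Compound 3 `O=C(Nc1cccc(-n2cc(-c3ccncc3)c(-c3ccc(Cl)c(O)c3)n2)c1)Nc1cc(C(F)(F)F)cc(C(F)(F)F)c1`: 6600 nM

Of the compounds shown here, three sharing one core have been tested in a functional assay on UO-31 cells (Homo sapiens) for inhibition, read by sulforhodamine B assay, with a stated time of 48 h; on this read-out higher numbers stand for lower toxicity in this test and lower numbers for higher toxicity in this test. Compound 1 gives > 32500 nM in this assay, which is a limit of the assay rather than a number. Compound 2 likewise reaches only > 32500 nM in this assay, again a limit. Compound 3 alone gives a measured figure, 6600 nM in this assay. Among the compounds with values here, compound 1 therefore stands at the limit of > 32500 nM in this assay, at which 2 of the 3 values shown sit, and no step between measured compounds can be drawn from these data. Compound 4 `O=C(Nc1cccc(-n2cc(-c3ccncc3)c(-c3ccc(Cl)c(O)c3)n2)c1)Nc1ccc(Cl)c(C(F)(F)F)c1` differs from compound 1 in one place: trifluoromethyl in place of chloro on an aromatic carbon. Within the data shown here, with compound 1 known only as a limit, the size of the step cannot be read from the numbers; compound 3 shows only that a value under the limit can be reached with this core. Compound 4 is expected to give about 20000 nM in this assay, within 6000 nM to 32500 nM. That would mean an expected step of an at least 1.6-fold lower number from compound 1 to compound 4 (0.21 log units; that floor lies within the scatter), with a result at the limit remaining quite possible.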

Compound 4, concentration lethal to 50% of the cells: > 32500 nM
Compound 4 was reported as a limit (the forecaster's own chance of this, stated with the estimate: 50%); at least 1.6-fold (0.21 log units) between middle value and limit.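

Compound 4, like compound 1, is reported only as a limit in this assay, so no step between the two can be read: the limit of > 32500 nM in this assay, at which 3 of the 4 values shown sit.

On these data alone, whether trifluoromethyl in place of chloro changes the result for the shared core in this assay remains open.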